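A few compounds are considered here, and "the series" means these few. Any claim that something is new, unique, unknown or untested is made for them only; others in the source may bear on it.

The three measured compounds and their values:

Compound 1, `O=C(Oc1cccc(F)c1OC(=O)c1cc(O)c(O)c(O)c1)c1cc(O)c(O)c(O)c1`: 81.1%
Compound 2, `O=C(Oc1ccc(Cl)cc1OC(=O)c1ccc(O)c(O)c1)c1ccc(O)c(O)c1`: 94.4%
Compound 3, `COc1cccc(OC(=O)c2ccccc2O)c1OC(=O)c1ccccc1O`: 50.5%

In a functional assay on NCI-H1299 cells (Homo sapiens) for inhibition, read by scintillation counting, with a stated time of 30 min, tested at 30 uM (a lower number here means less inhibition, a higher number more inhibition at the concentration tested (going by the name of the read-out)), compound 3 gives 50.5%, the lowest of the three numbers. Compound 1 gives 81.1%, a number beyond the scatter above compound 3, and compound 2 gives 94.4%, further still above it. Going by the values given here, no two of these three compounds differ in a single place, so no step between measured compounds can be read off.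

Compound 4, `O=C(Oc1cccc(OC(=O)c2ccccc2O)c1OC(=O)c1ccccc1O)c1ccccc1O`, has not yet been measured. It differs from compound 3 in one place: (2-hydroxyphenyl)carbonyl in place of methyl on an oxygen on an aromatic ring. The change adds a third ester of the same kind already present twice in compound 3, with its hydroxyl. Since the two compounds with higher numbers, compound 1 and compound 2, carry more hydroxyl groups than compound 3, the step from compound 3 to compound 4 is expected to run upward, of moderate size, and probably beyond the scatter, a number 13.5 percentage points higher from compound 3 to compound 4 (beyond the scatter). Compound 4 is therefore estimated to give 64%, expected between 42% and 84%.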

Compound 4, a percentage reported as inhibition, at one concentration (the size of the read-out at that concentration, not a potency): 74.7%
For compound 4 the middle estimate is 10.7 percentage points below the measured one; the range from low to high includes it.
By their numbers in this assay, from the lowest: compound 3; then compounds 4 and 1 (each within the scatter of the next); then compound 2.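

In this assay, (2-hydroxyphenyl)carbonyl in place of methyl on an oxygen on an aromatic ring gives a number 24.2 percentage points higher from compound 3 to compound 4 (beyond the scatter). Going by these compounds alone, this is the first change that can be read at a single place, which the earlier compounds, differing from one another in more than one place, could not offer. It shows that this oxygen carries a far larger group than methyl, one with an aromatic ring and a hydroxyl, without loss of inhibition at the concentration tested, though no measurement at hand says why the number rises.

The compounds shown leave open whether the gain needs the whole entering group or only part of it. A plain acetyl or an unsubstituted benzoyl on the same oxygen would separate the carbonyl and the ring from the hydroxyl, and an amine on that ring would test the hydroxyl's place.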